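This account rests on a few compounds, and the source may have more. Where it says the series, first, only, none or still open, it means among the compounds named here.

Compound 1 `Cc1ccc(S(=O)(=O)N(Cc2cccc(F)c2F)Cc2cn(S(=O)(=O)c3ccc(C)cc3)c3ccccc23)cc1`: -13.9%
Compound 2 `Cc1ccc(S(=O)(=O)n2cc(CN(Cc3ccccc3)Cc3cccc(F)c3F)c3ccccc32)cc1`: -13.1%
Compound 3 `Cc1ccc(S(=O)(=O)n2cc(CN(Cc3cccc(F)c3F)S(C)(=O)=O)c3ccccc32)cc1`: -3.3%

These numbers come from a functional assay on 3T3-L1 cells (Mus musculus) for inhibition, with a stated time of 20 min, tested at 20 uM; on this read-out higher numbers stand for more inhibition at the one concentration tested (going by the name of the read-out) and lower numbers for less inhibition. Compound 1 stands lowest of the three measured compounds: compound 2 lies a number 0.8 percentage points higher from compound 1 to compound 2 (within the scatter), and compound 3 lies a number 10.6 percentage points higher from compound 1 to compound 3 (beyond the scatter). None of the three shows inhibition at the concentration used.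

Compound 4 `Cc1ccc(S(=O)(=O)N(Cc2cn(Cc3ccccc3)nn2)Cc2cn(S(=O)(=O)c3ccc(C)cc3)c3ccccc23)cc1` has not yet been measured. It differs from compound 1 in one place: 1-benzyl-1H-1,2,3-triazol-4-yl in place of 2,3-difluorophenyl on a saturated chain carbon bound to a sulfonamide nitrogen. Among the compounds with values here, no measured step touches this part of the molecule: a number 0.8 percentage points higher from compound 1 to compound 2 (within the scatter) and a number 9.8 percentage points higher from compound 2 to compound 3 (within the scatter) change the group on the amine nitrogen, and a number 10.6 percentage points higher from compound 1 to compound 3 (beyond the scatter) changes the group on the sulfonyl sulfur. With all measured numbers sitting near zero, compound 4 is expected to stay close to them, a step of a number 7.9 percentage points higher from compound 1 to compound 4 (within the scatter) being expected, not beyond the scatter. Compound 4 is therefore estimated at -6%, within a range from -25% to 14%.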

Compound 4, a percentage reported as inhibition, at one concentration (the size of the read-out at that concentration, not a potency): 3.4%
For compound 4 the middle estimate is 9.4 percentage points below the measured one; the measured number falls inside the stated range.
By their numbers in this assay, from the lowest: compounds 1, 2, 3 and 4 (each within the scatter of the next, the first and the last beyond it).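

Changing the group on a saturated chain carbon bound to a sulfonamide nitrogen does register in this assay: 1-benzyl-1H-1,2,3-triazol-4-yl in place of 2,3-difluorophenyl gives a number 17.3 percentage points higher from compound 1 to compound 4 (beyond the scatter). Even so, compound 4 at 3.4% shows little inhibition at the one concentration tested. No measurement here bears on the cause of this step. Still open, going by these compounds, is whether the five-membered ring or its benzyl carries the step, and how 1-methyl-1H-1,2,3-triazol-4-yl or a carboxylic acid would read at this place.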